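Cyclopropyl for Isopropyl on the Acyl Sulfonamide Chain

A few compounds are considered here, and "the series" means these few. Any claim that something is new, unique, unknown or untested is made for them only; others in the source may bear on it.

Measured compounds:
Compound 1 `O=C(NS(=O)(=O)c1ccc(F)cc1)c1ccc(Nc2nc(NC3(c4ccc(Cl)cc4)CC3)nc(OCC(F)(F)F)n2)cc1`: 193 nm/s
Compound 2 `CC(C)(C)NC(=O)NCCS(=O)(=O)NC(=O)c1ccc(Nc2nc(NC3(c4ccc(Cl)cc4)CC3)nc(OCC(F)(F)F)n2)cc1`: 49 nm/s
Compound 3 `CC(C)C(=O)NCCS(=O)(=O)NC(=O)c1ccc(Nc2nc(NC3(c4ccc(Cl)cc4)CC3)nc(OCC(F)(F)F)n2)cc1`: 13 nm/s

In a physicochemical assay for permeability, using PAMPA, at pH 7.4 (a lower number here means that the compound crosses the layer more slowly, a higher number that the compound crosses the layer faster), compound 3 stands lowest of the three. Its nearest neighbour is compound 2, by a 3.8-fold lower number from compound 2 to compound 3 (0.58 log units; beyond the scatter), and the furthest is compound 1, by a 15-fold lower number from compound 1 to compound 3 (1.17 log units; beyond the scatter); the remaining step, a 3.9-fold lower number from compound 1 to compound 2 (0.60 log units; beyond the scatter), is of modest size.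

Compound 4 `O=C(NS(=O)(=O)CCNC(=O)C1CC1)c1ccc(Nc2nc(NC3(c4ccc(Cl)cc4)CC3)nc(OCC(F)(F)F)n2)cc1` differs from compound 3 by cyclopropyl in place of isopropyl on a carbonyl carbon. For the measured compounds named here, none of the measured steps makes this same exchange. Going by the values given here, the only step at that carbonyl carbon is a 3.8-fold lower number from compound 2 to compound 3 (0.58 log units; beyond the scatter), which replaced an amino group by a carbon group; the present change keeps a carbon group of the same kind and count, as the counted difference shows, with no donor or acceptor added or lost. The two larger steps both replaced the whole group on the sulfonyl sulfur and do not bear on it. The change is therefore expected to give a 1.2-fold higher number from compound 3 to compound 4 (0.06 log units; within the scatter), not beyond the scatter. Compound 4 is estimated at 15 nm/s, with a range from 6 nm/s to 35 nm/s.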

Compound 4, apparent permeability: 1 nm/s
Estimate against measurement, compound 4: 15-fold (1.18 log units) above; the measured number lies below the stated range.
By their numbers in this assay, from the lowest: compound 4; then compound 3; then compound 2; then compound 1.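

In this assay, putting cyclopropyl in place of isopropyl on a carbonyl carbon whose other neighbour is an amide-type nitrogen gives a 13-fold lower number from compound 3 to compound 4 (1.11 log units; beyond the scatter), a large step from an exchange that keeps the count of heavy atoms and adds no hydrogen-bond donor or acceptor. The earlier compounds shown here showed only an amino group giving way to a carbon group at this carbonyl carbon, whereas the step of a 49-fold lower number from compound 2 to compound 4 (1.69 log units; beyond the scatter) and the step above show that the number also depends on which carbon group stands there. With this chain on the sulfonyl sulfur in place of 4-fluorophenyl, the result is a 190-fold lower number from compound 1 to compound 4 (2.29 log units; beyond the scatter), the largest step in the set.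

Nothing measured here accounts for the drop on going to cyclopropyl. On these data alone, it remains open whether a cyclobutyl group or a longer carbon chain on the same carbonyl carbon would read like cyclopropyl or like isopropyl.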